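Extending the butyl ether of compound 1 with phenoxy

The compounds below may be only part of what the source reports. "The series", "measured", "known", "first", "only" and "open" are said of these compounds alone.

Values measured so far in a functional assay on a cell-free system (plasma, Homo sapiens) for inhibition, with Plasma (Rattus norvegicus) as the target (on this read-out lower numbers stand for stronger inhibition and higher numbers for weaker inhibition), are as follows.
Compound 1 `CCCCOc1ccc2c(N3CCNCC3)cc(=O)oc2c1C` gives 2790 nM
Compound 2 `O=c1cc(N2CCNCC2)c2cc(OCc3cccnc3)ccc2o1` gives 38000 nM
Compound 3 `Cc1c(OCc2ccccc2-c2ccccc2)ccc2c(N3CCNCC3)cc(=O)oc12` gives 17300 nM

Of these three compounds, compound 1 has the lowest number and so shows the strongest inhibition, with both others standing higher by more than the usual scatter. Compound 3 is its nearest neighbour on the scale, and compound 2 lies furthest away.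

The next compound to be tested is compound 4 `Cc1c(OCCOc2ccccc2)ccc2c(N3CCNCC3)cc(=O)oc12`, which departs from compound 1 in a single place: phenoxy in place of ethyl on a saturated chain carbon, two bonds along the chain from an oxygen on an aromatic ring. In words, phenoxy stands in place of ethyl on a saturated chain carbon, two bonds along the chain from an oxygen on an aromatic ring.

For the measured compounds named here, no measured pair isolates a change of this kind, so any forecast is indirect. The closest guide is that the group on the oxygen carries an aromatic ring in compound 3, at 17300 nM, and in compound 2, at 38000 nM, and both numbers are higher than that of compound 1. A moderate move toward weaker inhibition in this assay is therefore expected, and the estimated step is a 3.2-fold higher number from compound 1 to compound 4 (0.51 log units; beyond the scatter). For compound 4 the expected value is 9000 nM, with an estimated range from 3000 nM to 28000 nM.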

Compound 4, half-maximal inhibitory concentration: 9400 nM
Beside the measured number, compound 4's estimate is 1.0-fold (0.02 log units) below it, and the stated range covers the measured number.
By their numbers in this assay, from the lowest: compound 1; then compounds 4 and 3 (each within the scatter of the next); then compound 2.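

In this assay, for the compounds shown here, putting phenoxy in place of ethyl on a saturated chain carbon, two bonds along the chain from an oxygen on an aromatic ring, gives a 3.4-fold higher number from compound 1 to compound 4 (0.53 log units; beyond the scatter) and provides the first single-place comparison at this position. The earlier compounds shown here differed from compound 1 in more than one place, whereas this change, which can also be read as butyl to 2-phenoxyethyl, shows that adding phenoxy at the chain end on the core of compound 1 weakens inhibition only modestly, and compound 4 still gives a measured number (9400 nM). Nothing available explains why this step goes in this direction or has this size.

The single step changes chain length, an ether oxygen and an aromatic ring together, so the compounds shown do not separate their contributions; a plain longer chain such as hexyl, or a 3-phenylpropyl group with carbon in place of the chain oxygen, would bear on that. Also open, going by these compounds, is whether a terminal amine or a carboxylic acid in place of phenoxy would bring the number closer to that of compound 1 or move it further away.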